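The source may report more compounds than this note shows. Statements on the series, on what has been measured and on what is new or still open speak of the compounds shown alone.

The measured compounds are compound 1 `FC(F)(F)c1cccc(Cn2c(Cl)nc3cc(Cl)c(Cl)cc32)c1`, compound 2 `O=[N+]([O-])c1cccc(Cn2c(Cl)nc3cc(Cl)c(Cl)cc32)c1` and compound 3 `FC(F)(F)c1cccc(Cn2c(Br)nc3cc(Cl)c(Cl)cc32)c1`.

In a functional assay on CEM-SS cells (Homo sapiens) for cytotoxicity (a higher number here means a weaker inhibitor, a lower number a stronger inhibitor), compound 1 gives > 100000 nM, which is a limit of the assay and not a number. In this assay compound 2 gives > 100000 nM, again only a limit. In this assay compound 3 gives > 100000 nM, also a limit. The change from compound 1 to compound 2 is nitro in place of trifluoromethyl on an aromatic carbon, and the step it made is a step that the two limits leave unreadable from compound 1 to compound 2. The cores of compound 1 and compound 3 differ by bromo in place of chloro on an aromatic carbon, with the step that the two limits leave unreadable from compound 1 to compound 3. All three values sit at the limit of > 100000 nM in this assay, at which 3 of the 3 values shown sit.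

Compound 4 `O=[N+]([O-])c1cccc(Cn2c(Br)nc3cc(Cl)c(Cl)cc32)c1` has not yet been measured. It differs from compound 3 by nitro in place of trifluoromethyl on an aromatic carbon, the same change as from compound 1 to compound 2, at the same place. Beside that earlier step, the step in this assay is expected to be a step that the limit leaves unreadable from compound 3 to compound 4, an expectation resting only on the three measured values all lying at the limit of > 100000 nM in this assay, at which 3 of the 3 values shown sit. Compound 4 is accordingly expected to show about 200000 nM in this assay, between 100000 nM and 1000000 nM, most probably reported again as a limit.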

Compound 4, half-maximal inhibitory concentration: > 100000 nM
Compound 4: a limit, no number; the forecaster's own chance of this, stated with the estimate: 90%; the middle value does not contradict the limit.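

In this assay compound 4 gives > 100000 nM, again a limit of the assay and not a number. Its steps from compound 3 and from compound 2 therefore cannot be read, and the four compounds share one position: the limit of > 100000 nM in this assay, at which 4 of the 4 values shown sit.

The compounds shown leave open whether swapping nitro for trifluoromethyl, or bromo for chloro, changes anything in this assay.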